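The source may report more compounds than this note shows. Statements on the series, on what has been measured and on what is new or still open speak of the compounds shown alone.

The study follows a small series of trimethoxyphenyl ketones that share one core. Compound 1 `COc1cc(C(=O)c2cn(-c3cccc(C)c3)cc2-c2ccoc2)cc(OC)c1OC` and compound 2 `COc1cc(C(=O)c2cn(-c3ccc(F)cc3)cc2-c2ccoc2)cc(OC)c1OC` differ only in the aryl group on the aromatic nitrogen. In a functional assay on MCF7 cells (Homo sapiens) for inhibition, with a stated time of 96 h (on this read-out higher numbers stand for weaker inhibition and lower numbers for stronger inhibition), compound 1 gives 21 nM, and in this assay compound 2 gives 15 nM. Within the data shown here, the step of a 1.4-fold lower number from compound 1 to compound 2 (0.15 log units; within the scatter) places the two within the scatter of each other, so compound 2 simply holds the lower of the two numbers, with compound 1 as its only neighbour.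

Compound 3 `COc1cc(C(=O)c2cn(-c3ccc(F)cc3)cc2-c2ccccn2)cc(OC)c1OC` keeps the 4-fluorophenyl group of compound 2 and changes the other ring: pyridin-2-yl in place of furan-3-yl on an aromatic carbon. Among the measured compounds shown here, no measured step touches this position; the single step in hand, a 1.4-fold lower number from compound 1 to compound 2 (0.15 log units; within the scatter), concerns the aryl group on the nitrogen and was within the scatter. The account therefore carries no evidence on how the pyridin-2-yl ring will read out in this assay, and the expectation rests on the shared core alone.

On that basis compound 3 is expected to give 22 nM, with a range of 6 nM to 80 nM, which means an estimated step of a 1.5-fold higher number from compound 2 to compound 3 (0.17 log units; within the scatter) that stays near the scatter of the series.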

Compound 3, half-maximal inhibitory concentration: 73 nM
The estimate for compound 3 lay 3.3-fold (0.52 log units) below the measured number, within the range that was stated.
By their numbers in this assay, from the lowest: compounds 2 and 1 (each within the scatter of the next); then compound 3.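

Among these compounds, the earlier compounds showed only that changing the aryl group on the aromatic nitrogen gave a 1.4-fold lower number from compound 1 to compound 2 (0.15 log units; within the scatter) in this assay; the new result shows that the aromatic carbon bearing the other ring can also move the read-out. With the 4-fluorophenyl group held fixed, pyridin-2-yl in place of furan-3-yl gives a 4.9-fold higher number from compound 2 to compound 3 (0.69 log units; beyond the scatter), a modest change that lies beyond the scatter and so makes this ring exchange, a five-membered aromatic ring with an oxygen giving way to a six-membered aromatic ring with a nitrogen, a real loss of inhibition in this single pair. No measurement in hand accounts for this loss, and the pair cannot separate the size of the ring from the identity of its hetero atom.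

The compounds shown leave open whether a plain phenyl ring, a pyridin-3-yl ring or a furan-2-yl ring at this position would read closer to compound 2 or to compound 3. They also leave open whether the same exchange would give a step of similar size with the 3-methylphenyl group of compound 1 on the nitrogen.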